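Alkoxy chain variation on a shared trimethoxyphenyl chromone core

The compounds below may be only part of what the source reports. "The series", "measured", "known", "first", "only" and "open" are said of these compounds alone.

Measured so far:
- compound 1, `CCCCCOc1c(-c2cc(OC)c(OC)c(OC)c2)oc2ccccc2c1=O`: in a functional assay on DU-145 cells (Homo sapiens) for antiproliferative activity, read by WST assay, with a stated time of 3 days (on this read-out higher numbers stand for weaker inhibition and lower numbers for stronger inhibition), compound 1 gives > 50000 nM, which is a limit of the assay
- compound 2, `CCCCCCCOc1c(-c2cc(OC)c(OC)c(OC)c2)oc2ccccc2c1=O`: in this assay compound 2 gives > 50000 nM, which is a limit of the assay
- compound 3, `CCN(CC)CCCOc1c(-c2cc(OC)c(OC)c(OC)c2)oc2ccccc2c1=O`: in this assay compound 3 gives > 50000 nM, which is a limit of the assay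

Compound 3 stands at the limit together with every other measured member of the series; the limit of > 50000 nM in this assay, at which 3 of the 3 values shown sit, holds for all three, so none of the three can be set in order against the others. The steps between them, a step that the two limits leave unreadable from compound 1 to compound 2, a step that the two limits leave unreadable from compound 1 to compound 3 and a step that the two limits leave unreadable from compound 2 to compound 3, are unreadable for that reason: both ends of each sit at the limit.

Compound 4, `CCCN(CCC)CCCCOc1c(-c2cc(OC)c(OC)c(OC)c2)oc2ccccc2c1=O`, differs from compound 3 by (dipropylamino)methyl in place of diethylamino on a saturated chain carbon, three bonds along the chain from an oxygen on an aromatic ring. Among the compounds with values here, no measured step bears readably on this change, since every value shown is a limit. Nothing therefore points to a gain that would bring compound 4 below the limit, and the expected step of a number no higher from compound 3 to compound 4 (the limit leaves the size open) is essentially none beyond the scatter. Compound 4 is expected to give about 50000 nM in this assay, within 15000 nM to 150000 nM, most likely again as a limit rather than a number.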

Compound 4, half-maximal inhibitory concentration: 35800 nM
Beside the measured number, compound 4's estimate is 1.4-fold (0.15 log units) above it; low and high end bracket the measured number.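

In this assay, within the data shown here, compound 4 gives 35800 nM, the only value shown that is a number rather than a limit, so this position can carry a group, here 4-(dipropylamino)butyl in place of 3-(diethylamino)propyl, that gives a readable result. The steps now readable are an at least 1.3-fold lower number from compound 3 to compound 4 (0.14 log units; that floor lies within the scatter), an at least 1.3-fold lower number from compound 2 to compound 4 (0.14 log units; that floor lies within the scatter) and an at least 1.3-fold lower number from compound 1 to compound 4 (0.14 log units; that floor lies within the scatter), so none of them establishes a real gain. Each gives only a floor, because its other end remains a limit: the limit of > 50000 nM in this assay, at which 3 of the 4 values shown sit.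

From the compounds shown here alone, the step from compound 3 to compound 4 alters the chain and the amine together, so the share of each stays open. A 4-(diethylamino)butyl or 3-(dipropylamino)propyl group would separate the two, and a cyclic amine such as piperidine on the same chain remains an open question.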